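This account rests on a few compounds, and the source may have more. Where it says the series, first, only, none or still open, it means among the compounds named here.

Compound 1 `N#Cc1ncn(-c2ccc(F)cc2)c1/N=C/c1ccc(O)cc1` and compound 2 `COc1ccc(/C=N/c2c(C#N)ncn2-c2ccc(F)cc2)cc1` share one core; in a functional assay on MCF7 cells (Homo sapiens) for antiproliferative activity, read by MTT assay, with a stated time of 48 h (a higher number here means a weaker inhibitor, a lower number a stronger inhibitor), compound 1 gives 11500 nM and compound 2 gives 9330 nM. The change between them, (methyl in place of hydrogen on an oxygen on an aromatic ring), produced a 1.2-fold lower number from compound 1 to compound 2 (0.09 log units; within the scatter). Compound 3 `COc1ccc(/C=N/c2c(C#N)ncn2Cc2ccc(F)cc2)cc1O` is built on a different core; the difference between the two cores is not broken down here. In this assay compound 3 gives 4530 nM, the lowest of the three numbers. Compound 4 `COc1ccc(/C=N/c2c(C#N)ncn2Cc2ccc(F)cc2)cc1OC` repeats the same change on the core of compound 3, (methyl in place of hydrogen on an oxygen on an aromatic ring), at a place described in the same words as before. Since the earlier step of a 1.2-fold lower number from compound 1 to compound 2 (0.09 log units; within the scatter) stayed within the scatter, the step from compound 3 to compound 4 is expected to be a 1.2-fold lower number from compound 3 to compound 4 (0.08 log units; within the scatter). Compound 4 is therefore estimated at 3800 nM in this assay, between 1900 nM and 8000 nM.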

Compound 4, half-maximal inhibitory concentration: 11100 nM
The estimate for compound 4 lay 2.9-fold (0.47 log units) below the measured number; the whole stated range lies below it.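

In this assay, going from hydroxy to methoxy gave a 2.5-fold higher number from compound 3 to compound 4 (0.39 log units; beyond the scatter) on the core of compound 3, so the near-silent result on the core of compound 1 did not carry over. The two steps differ by more than repeated measurement would explain: the same change on two cores in this assay, a 1.2-fold lower number (0.09 log units; within the scatter) from compound 1 to compound 2 and a 2.5-fold higher number (0.39 log units; beyond the scatter) from compound 3 to compound 4, 3.0-fold (0.48 log units) apart, beyond the scatter of two such steps. This shows that the outcome of the change depends on the core in these compounds, but with a single pair on each core it does not show which difference between the cores matters, nor how general the dependence is.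

The compounds shown leave open whether an ethoxy group or a longer chain on that oxygen would follow the step seen on either core. Going by these compounds, whether an amine in place of the hydroxy would do so also remains open.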